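Trading a fused bicyclic aryl group for imidazolyl

A few compounds are considered here, and "the series" means these few. Any claim that something is new, unique, unknown or untested is made for them only; others in the source may bear on it.

Of the compounds shown here, three built on one shared core have been measured in an assay on CHO cells for antagonist activity at transient receptor potential cation channel subfamily V member 1 (Homo sapiens), read by FLIPR; a higher number here means a weaker inhibitor, a lower number a stronger inhibitor. Compound 1 `CC(C(=O)NCc1ccc(C(F)(F)F)nc1-c1ccccc1)c1ccc(NS(C)(=O)=O)c(F)c1` carries a plain phenyl on the core and gives 6.4 nM. Compound 2 `CC(C(=O)NCc1ccc(C(F)(F)F)nc1-c1ccc(C(C)(C)C)cc1)c1ccc(NS(C)(=O)=O)c(F)c1` bears a tert-butyl on that phenyl and gives 0.5 nM. Compound 3 `CC(C(=O)NCc1ccc(C(F)(F)F)nc1-c1ccc2c(c1)OCCO2)c1ccc(NS(C)(=O)=O)c(F)c1` gives 5 nM, which places it second highest of the three, close to compound 1 and far from compound 2.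

Compound 4 `CC(C(=O)NCc1ccc(C(F)(F)F)nc1-n1ccnc1)c1ccc(NS(C)(=O)=O)c(F)c1` differs from compound 3 in one place: 1H-imidazol-1-yl in place of 2,3-dihydro-1,4-benzodioxin-6-yl on an aromatic carbon. Of the measured steps, a 1.3-fold lower number from compound 1 to compound 3 (0.11 log units; within the scatter) shows that swapping phenyl for the fused bicyclic group changed little, whereas a 13-fold lower number from compound 1 to compound 2 (1.11 log units; beyond the scatter) and a 10-fold higher number from compound 2 to compound 3 (1.00 log units; beyond the scatter) show that a bulky aryl substituent matters a great deal. For the measured compounds named here, no measured step replaces the aryl group with a small five-membered heteroaromatic ring, so the step is uncertain. A moderate weakening, a 4.0-fold higher number from compound 3 to compound 4 (0.60 log units; beyond the scatter), is expected, since the gains seen came from larger groups. Compound 4 is therefore estimated at 20 nM, with a range from 4 nM to 100 nM.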

Compound 4, inhibition constant: 36.1 nM
Estimate against measurement, compound 4: 1.8-fold (0.26 log units) below; the range from low to high includes it.
By their numbers in this assay, from the lowest: compound 2; then compounds 3 and 1 (each within the scatter of the next); then compound 4.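

The 1H-imidazol-1-yl group, a five-membered aromatic ring with two hetero atoms, makes a weaker inhibitor than any of the three groups built on a six-membered aromatic ring of carbon only, with a 7.2-fold higher number from compound 3 to compound 4 (0.86 log units; beyond the scatter) and a 5.6-fold higher number from compound 1 to compound 4 (0.75 log units; beyond the scatter) and, against the best of them, a 72-fold higher number from compound 2 to compound 4 (1.86 log units; beyond the scatter). For the compounds shown here, earlier changes at this position, next to the ring nitrogen, either left the number within the scatter or lowered it, so this is the first sign that a change here can also cost activity. Nothing available here explains the loss.

Still open, as far as these compounds go, is whether the loss goes with the five-membered ring or with its two nitrogens, which a 2-thienyl or 3-pyridyl group at this position could help separate. Also open, from the compounds shown here alone, is whether a tert-butyl on the imidazole ring would bring back activity, as it did on phenyl.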